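Moving the Phenyl Substituent: From Bromo to Methyl

The compounds below may be only part of what the source reports. "The series", "measured", "known", "first", "only" and "open" are said of these compounds alone.

Going by the values given here, compound 1 `CC1(C)[C@H]2CC[C@]1(C)N(Cc1cn(-c3ccccc3Br)nn1)C(=O)C2` sits second highest of the three numbers so far in a functional assay on LoVo cells (Homo sapiens) for inhibition, read by MTT assay, with a stated time of 24 h (on this read-out lower numbers stand for stronger inhibition and higher numbers for weaker inhibition), where compound 1 gives 60 nM. Its nearest neighbour is compound 3 `CC1(C)[C@H]2CC[C@]1(C)N(Cc1cn(-c3ccccc3)nn1)C(=O)C2`, which in this assay gives 50 nM; the step of a 1.2-fold lower number from compound 1 to compound 3 (0.08 log units; within the scatter) lies within the scatter. The furthest is compound 2 `CC1(C)[C@H]2CC[C@]1(C)N(Cc1cn(-c3ccccc3Cl)nn1)C(=O)C2`, which gives 190 nM; the step of a 3.2-fold higher number from compound 1 to compound 2 (0.50 log units; beyond the scatter) is a modest worsening, and the step of a 3.8-fold lower number from compound 2 to compound 3 (0.58 log units; beyond the scatter) returns to the better end.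

Compound 4 `Cc1cccc(-n2cc(CN3C(=O)C[C@@H]4CC[C@@]3(C)C4(C)C)nn2)c1` differs from compound 1 in one place: 3-methylphenyl in place of 2-bromophenyl on an aromatic nitrogen. Among the compounds with values here, no measured step covers a methyl group on this ring, nor a move away from the position carried by the bromo and chloro groups. Within the data shown here, the steps that bear on it are the swaps at that ring: hydrogen for bromo changed nothing beyond the scatter, while chloro for bromo gave a modest rise. The ring therefore seems to accept changes, but not uniformly, so an unfamiliar substituent in an unfamiliar position could fall anywhere within that span. The expected step is a 1.3-fold higher number from compound 1 to compound 4 (0.12 log units; within the scatter), a small shift with wide uncertainty. Compound 4 is therefore estimated at 80 nM, expected to fall between 30 nM and 250 nM.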

Compound 4, half-maximal inhibitory concentration: 50 nM
The estimate for compound 4 lay 1.6-fold (0.20 log units) above the measured number; low and high end bracket the measured number.
By their numbers in this assay, from the lowest: compounds 3, 4 and 1 (each within the scatter of the next); then compound 2.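

In this assay, going by these compounds alone, the phenyl ring on the aromatic nitrogen also takes a methyl group, a kind of substituent the earlier compounds did not show: no change at the digits printed from compound 3 to compound 4 (within the scatter) and a 1.2-fold lower number from compound 1 to compound 4 (0.08 log units; within the scatter) both stay within the scatter, so 3-methylphenyl, unsubstituted phenyl and 2-bromophenyl cannot be told apart at this position. With a 3.8-fold lower number from compound 2 to compound 4 (0.58 log units; beyond the scatter) beyond the scatter, compound 2 is left alone as the weakest of the four, and its 2-chlorophenyl group is the one exception to the tolerance seen with the other three groups. Nothing available explains why the 2-chlorophenyl group stands apart from the others or why the methyl group leaves the number in the range of compound 3.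

As far as these compounds go, it remains open whether a methyl group elsewhere on this ring would read the same as the 3-methylphenyl group does, and therefore whether the result belongs to the methyl group or to its place. From the compounds shown here alone, it also remains open whether the ring would accept an amine or a carboxylic acid as readily as it accepts methyl.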